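The source may hold more compounds than are shown below. What is called first, only, known or untested is meant among the compounds shown, and "the series" means these compounds.

Measured so far in a functional assay on the whole organism (Tail, strain ICR) with Mus musculus as the target, in the tail flick test, with a stated time of 90 min, at a dose of 25 umol/kg by the oral route; a higher number here means a stronger effect of the compound at the dose given, a lower number a weaker effect:
compound 1 `C[C@H](NC(=O)CN(c1nc(Cl)nc2[nH]cnc12)C1CC1)C(=O)OCc1ccccc1`: 44.2%
compound 2 `O=C(O)[C@@H]1CCCN1C(=O)CN(c1nc(Cl)nc2[nH]cnc12)C1CC1`: 26%

Compound 1 stands highest of the two numbers in this assay, with compound 2 lying lower by more than the scatter. Compound 3 `CC(C)[C@H](NC(=O)CN(c1nc(Cl)nc2[nH]cnc12)C1CC1)C(=O)OCc1ccccc1` has not yet been measured in this assay. It differs from compound 1 in one place: isopropyl in place of methyl on a saturated chain carbon bound to an amide-type nitrogen and a carbonyl carbon. Going by the values given here, no pair of measured compounds shows a step of this kind, so its size is unknown from the data. The step of a number 4.2 percentage points lower from compound 1 to compound 3 (within the scatter) is expected to be small, within the scatter or a slight fall. Compound 3 is estimated at 40%, in the range 20% to 60%.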

Compound 3, a percentage reported as activity, at one dose (the size of the read-out at that dose, not a potency): 51.3%
Compound 3: the middle estimate sits 11.3 percentage points below what was measured; low and high end bracket the measured number.
By their numbers in this assay, from the lowest: compound 2; then compounds 1 and 3 (each within the scatter of the next).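

In this assay, isopropyl in place of methyl on a saturated chain carbon bound to an amide-type nitrogen and a carbonyl carbon gives a number 7.1 percentage points higher from compound 1 to compound 3 (within the scatter). Going by these compounds alone, this is the first step read at this position, and it shows that, at this dose and time, the effect in the tail flick test holds with either group. Nothing measured here gives a reason for this result.

From the compounds shown here alone, whether a longer chain, a phenyl ring or an amine on this carbon would keep the effect remains open. So does whether the step would stay this small at another dose or time.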